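Hydroxymethyl to carboxy on the pyrazole-type core, Z-138 series

A few compounds are considered here, and "the series" means these few. Any claim that something is new, unique, unknown or untested is made for them only; others in the source may bear on it.

Measured compounds:
compound 1 `O=C(CCl)N1CCCC(n2nc(-c3ccc(Oc4ccccc4)cc3)cc2CO)C1` — 400 nM
compound 2 `C=CC(=O)Nc1ccc(Cn2nc(-c3ccc(Oc4ccccc4)cc3)cc2C(=O)O)cc1` — > 60000 nM

In a functional assay on Z-138 cells (Homo sapiens) for inhibition, read by luminescence and CellTiter-Glo, with a stated time of 72 h (on this read-out higher numbers stand for weaker inhibition and lower numbers for stronger inhibition), compound 1 gives 400 nM. For the measured compounds named here, compound 1 holds the only numerical value; the one other entry is a limit. For compound 2 the assay reports only a limit, > 60000 nM, and not a number (the limit of > 60000 nM in this assay, at which 1 of the 2 values shown sits).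

Compound 3 `O=C(O)c1cc(-c2ccc(Oc3ccccc3)cc2)nn1C1CCCN(C(=O)CCl)C1` is not yet measured. It differs from compound 1 by carboxy in place of hydroxymethyl on an aromatic carbon; the chloroacetyl piperidine and the phenoxyphenyl part of compound 1 are retained. Going by the values given here, no measured pair shows this change in isolation, so the size of the step is open. Compound 3 is expected to show weaker inhibition than compound 1 in this assay, with a step of a 6.3-fold higher number from compound 1 to compound 3 (0.80 log units; beyond the scatter) estimated, beyond the usual scatter. Compound 3 is estimated at 2500 nM, within 500 nM to 20000 nM.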

Compound 3, half-maximal inhibitory concentration: 2800 nM
Compound 3: the middle estimate sits 1.1-fold (0.05 log units) below what was measured; the range from low to high includes it.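

In this assay, this pair gives the first size for the change, with only the group on the aromatic carbon differing: a 7.0-fold higher number from compound 1 to compound 3 (0.85 log units; beyond the scatter). The step is modest, and compound 3 still gives a number, 2800 nM, rather than a limit, so this carbon, next to the ring atom that bears a 1-((chloromethyl)carbonyl)piperidin-3-yl group, accepts carboxy with a measurable read-out. Nothing shown gives a measured property that bears on this step.

Open, from the compounds shown here alone, is where a methyl ester, a primary amide or an aminomethyl group on this carbon would fall relative to compound 1 and compound 3. Also open, going by these compounds, is whether the step keeps its size when the 1-((chloromethyl)carbonyl)piperidin-3-yl group gives way to another chain, such as an acrylamide.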